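A few compounds are considered here, and "the series" means these few. Any claim that something is new, unique, unknown or untested is made for them only; others in the source may bear on it.

Working notes on the series. Compound 1 `CCCCOCCOC1CCN(c2nc(N)c3cc(OC)c(OC)cc3n2)CC1` gives 1.03 nM in an assay on brain for displacement of a labelled ligand from Adrenergic receptor alpha-1 (Rattus norvegicus); on this read-out higher numbers stand for weaker inhibition and lower numbers for stronger inhibition. Among the compounds with values here, compound 2 `COc1cc2nc(N3CCC(OCCOc4ccccc4)CC3)nc(N)c2cc1OC` gives 0.48 nM in this assay, and it stands as the lowest of the two numbers at hand; its nearest neighbour is compound 1, and the change a 2.1-fold lower number from compound 1 to compound 2 (0.33 log units; beyond the scatter) is the only measured step, with phenyl in place of butyl on an oxygen on a saturated carbon.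

Compound 3 `COc1cc2nc(N3CCC(OCC(C)OC)CC3)nc(N)c2cc1OC` has not yet been measured in this assay. The change from compound 2 to compound 3 is 1-methoxyethyl in place of phenoxymethyl on a saturated chain carbon bound to an oxygen on a saturated carbon. The step from compound 1 to compound 2 bears on it in part: that step gained from putting a phenyl where a butyl had been, and compound 3 again lacks the aromatic ring, carrying a shorter chain with the same count of acceptors. The expectation for compound 3 is therefore a modest move back toward the number of compound 1, so a step of a 3.1-fold higher number from compound 2 to compound 3 (0.49 log units; beyond the scatter) is estimated, toward a higher number rather than a lower one. For compound 3 an inhibition constant of 1.5 nM is estimated, with a range from 0.6 nM to 4 nM.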

Compound 3, inhibition constant: 1.41 nM
The estimate for compound 3 lay 1.1-fold (0.03 log units) above the measured number; low and high end bracket the measured number.
By their numbers in this assay, from the lowest: compound 2; then compounds 1 and 3 (each within the scatter of the next).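

Replacing phenoxymethyl with 1-methoxyethyl on a saturated chain carbon bound to an oxygen on a saturated carbon gives a 2.9-fold higher number from compound 2 to compound 3 (0.47 log units; beyond the scatter) in this assay, so the lower number of compound 2 is now set off from two chains without a ring, not from the butoxymethyl chain alone. Replacing butoxymethyl with the same 1-methoxyethyl gives a 1.4-fold higher number from compound 1 to compound 3 (0.14 log units; within the scatter), which shows that at this place the much shorter branched chain and the butoxymethyl chain cannot be told apart on this read-out, and that shortening the chain alone produces no measurable move. Nothing at hand explains the difference that goes with the phenoxymethyl group.

Phenoxymethyl is the only group here with an aromatic ring, so the three compounds do not separate the ring itself from the oxygen that joins it to the chain, and a benzyloxymethyl, cyclohexyloxymethyl or pyridyloxymethyl group would bear on this. The methyl branch of 1-methoxyethyl also remains unseparated from the chain length, a question that an unbranched 2-methoxyethyl group would address.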